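The compounds below may be only part of what the source reports. "The series", "measured", "known", "first", "only" and "open" are said of these compounds alone.

Working notes on the series. In a functional assay on CHO-K1 cells with Glucose-dependent insulinotropic receptor (Homo sapiens) as the target, read by a luciferase reporter, with a stated time of 5 h (a higher number here means a larger maximal response, a lower number a smaller maximal response), compound 1 `CC(C)(C)OC(=O)N1CCC(Oc2cccc3c2ccn3-c2ccc(S(C)(=O)=O)cc2)CC1` gives 28%. Compound 2 `CC(C)OC(=O)N1CCC(Oc2ncnc3c2CCN3c2ccc(S(C)(=O)=O)cc2)CC1`, built on a different core, gives 154% in this assay, and compound 3 `CC(C)(C)OC(=O)N1CCC(Oc2ncnc3c2CCN3c2ccc(S(C)(=O)=O)cc2F)CC1` gives 139%. Among these three numbers compound 3 stands second highest; its nearest neighbour is compound 2, which lies above it by a gap beyond the usual scatter, and its furthest is compound 1, which lies far below it, again beyond the scatter.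

Compound 4 `CCSC(=O)N1CCC(Oc2ncnc3c2CCN3c2ccc(S(C)(=O)=O)cc2F)CC1` differs from compound 3 in one place: ethylsulfanyl in place of tert-butoxy on a carbonyl carbon. Among the measured compounds shown here, no measured pair in the set shows this change, so the step has to be judged from the surroundings only. Compound 2 and compound 3 both carry an oxygen-linked group on that carbonyl carbon and both give large maximal responses, while nothing in the set tells how a sulfur-linked group there behaves. The expectation is that the step of a number 19 percentage points lower from compound 3 to compound 4 (beyond the scatter) is small to moderate and downward, with a fair chance that it stays within the scatter. For compound 4 the estimate in this assay is 120%, with a range from 80% to 160%.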

Compound 4, largest response reached (reported as percent of maximum), in percent of the reference or control that the assay uses: 128%
The estimate for compound 4 lay 8 percentage points below the measured number; low and high end bracket the measured number.
By their numbers in this assay, from the lowest: compound 1; then compound 4; then compound 3; then compound 2.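

In this assay, ethylsulfanyl in place of tert-butoxy on a carbonyl carbon gives a number 11 percentage points lower from compound 3 to compound 4 (beyond the scatter), a modest step, and compound 4 still reaches 128%. Among the compounds shown here, this is the only pair that differs in one place, and it shows that a large maximal response does not depend on an oxygen-linked group on this carbonyl carbon, nor on the 5 heavy atoms of tert-butoxy, since a sulfur-linked group of 3 heavy atoms also gives one. No supporting data bear on why the step has this size.

The change swaps the linking atom and the size of the group together, so the compounds shown leave open which of the two accounts for the step; ethoxy or ethylamino on the same carbonyl carbon would separate these two parts of the change. Also open, from the compounds shown here alone, is whether a longer sulfur-linked chain, such as propylsulfanyl or butylsulfanyl, would hold the maximal response of compound 4 or move it further from that of compound 3.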